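This account rests on a few compounds, and the source may have more. Where it says the series, first, only, none or still open, it means among the compounds named here.

Going by the values given here, in a functional assay on PC-3 cells (Homo sapiens) for cytotoxicity, read by sulforhodamine B assay, with a stated time of 5 days (a lower number here means a stronger inhibitor, a higher number a weaker inhibitor), compound 2 `O=C(CCCCCCc1ccccc1)CC(=O)N[C@H]1CCOC1=O` gives 9000 nM, the lower of the two numbers so far, while compound 1 `O=C(CCCCc1ccccc1)CC(=O)N[C@H]1CCOC1=O` gives 83000 nM. Compound 3 `O=C(CCCCCCCCCc1ccccc1)CC(=O)N[C@H]1CCOC1=O` extends the same chain further, with 3-phenylpropyl in place of phenyl on a saturated chain carbon, six bonds along the chain from a carbonyl carbon. Among the compounds with values here, only one measured step bears on this change: a 9.2-fold lower number from compound 1 to compound 2 (0.96 log units; beyond the scatter), where phenethyl replaces phenyl on a saturated chain carbon, four bonds along the chain from a carbonyl carbon. That step also lengthened the chain and lowered the number. A single step cannot show whether the trend continues, so a further fall in this assay is expected, though probably a smaller one, and no real change remains possible. The expected change is a 3.6-fold lower number from compound 2 to compound 3 (0.56 log units; beyond the scatter). For compound 3 the estimated value is 2500 nM, with an expected range from 500 nM to 12000 nM.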

Compound 3, half-maximal inhibitory concentration: 4000 nM
Compound 3: the middle estimate sits 1.6-fold (0.20 log units) below what was measured, within the range that was stated.
By their numbers in this assay, from the lowest: compound 3; then compound 2; then compound 1.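

In this assay, extending the chain once more, with 3-phenylpropyl in place of phenyl, still moves the number down, giving a 2.3-fold lower number from compound 2 to compound 3 (0.35 log units; beyond the scatter). The earlier step, a 9.2-fold lower number from compound 1 to compound 2 (0.96 log units; beyond the scatter), was therefore no one-off: across these three compounds, each longer chain gives a lower number and none goes against that order, though the newer step is the smaller of the two. Nothing measured here explains why the added chain carbons have this effect.

From the compounds shown here alone, whether a still longer chain would lower the number further, level off or reverse the trend remains open. It is also unclear whether the phenyl at the chain end matters at all, since a plain alkyl end, an amine or a carboxylic acid in that place could behave quite differently.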